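Branching the Amide Side Chain: Phenyl Gives Way to Isopropyl

The compounds below may be only part of what the source reports. "The series", "measured", "known", "first", "only" and "open" are said of these compounds alone.

Compound 3 `COC(=O)[C@H](NC(=O)c1[nH]cnc1C(=O)Nc1ccc(Cl)c(Cl)c1)c1ccccc1` shows the highest of the two numbers in a functional assay on HL-60 cells (Homo sapiens), with a stated time of 2 days (on this read-out higher numbers stand for weaker inhibition and lower numbers for stronger inhibition), giving 17300 nM. Compound 1 `CCCCCCNC(=O)c1[nH]cnc1C(=O)Nc1ccc(Cl)c(Cl)c1` is nearest, giving 14600 nM, which lies within the scatter of compound 3. Compound 2 `COC(=O)[C@@H](C)NC(=O)c1[nH]cnc1C(=O)Nc1ccc(Cl)c(Cl)c1` returns only an assay limit of > 62500 nM. The step of an at least 4.2-fold higher number from compound 1 to compound 2 (0.63 log units; beyond the scatter) runs into (the limit of > 62500 nM in this assay, at which 1 of the 3 values shown sits). Compound 4 `COC(=O)[C@H](NC(=O)c1[nH]cnc1C(=O)Nc1ccc(Cl)c(Cl)c1)C(C)C` differs from compound 3 by isopropyl in place of phenyl on a saturated chain carbon bound to an amide-type nitrogen and a carbonyl carbon. Among the measured compounds shown here, the one measured step at this place is an at least 3.6-fold lower number from compound 2 to compound 3 (0.55 log units; beyond the scatter), which went from methyl to phenyl. Moving back from phenyl toward an alkyl group, isopropyl, is expected to raise the number modestly, a 1.7-fold higher number from compound 3 to compound 4 (0.24 log units; within the scatter). Compound 4 is estimated at 30000 nM in this assay, with a range from 12000 nM to 70000 nM.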

Compound 4, half-maximal inhibitory concentration: 8500 nM
The estimate for compound 4 lay 3.5-fold (0.55 log units) above the measured number, and the stated range ends above it.
By their numbers in this assay, from the lowest: compounds 4, 1 and 3 (each within the scatter of the next, the first and the last beyond it). At a limit, above all of these: compound 2.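

At this saturated chain carbon, an aromatic ring is not needed for the lower numbers in this assay: isopropyl outdoes phenyl (a 2.0-fold lower number from compound 3 to compound 4 (0.31 log units; beyond the scatter)). Set against the unbranched hexyl amide, the isopropyl side chain gives no separable difference (a 1.7-fold lower number from compound 1 to compound 4 (0.23 log units; within the scatter)). The gain over the methyl side chain (an at least 7.3-fold lower number from compound 2 to compound 4 (0.86 log units; beyond the scatter)) starts from a limit of the assay, not a number: the limit of > 62500 nM in this assay, at which 1 of the 4 values shown sits.

The compounds shown leave open whether a tert-butyl or a benzyl group at this carbon would lower the number further. They also leave open whether a carboxylic acid in place of the methyl ester would keep it.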